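The source may report more compounds than this note shows. Statements on the series, on what has been measured and on what is new or still open speak of the compounds shown alone.

Compound 1 `COc1ccc(C(=O)/C(=C/c2ccc(Cl)cc2Cl)CCOC(C)=O)cc1` gives 83400 nM in a functional assay on MCF7 cells (Homo sapiens) for inhibition, read by XTT assay, with a stated time of 48 h; on this read-out higher numbers stand for weaker inhibition and lower numbers for stronger inhibition.
Compound 2 `COc1ccc(C(=O)/C(=C/c2c(F)c(F)c(F)c(F)c2F)CCOC(C)=O)cc1` gives only a limit of this assay, > 100000 nM.
Compound 3 `COc1ccc(C(=O)/C(=C/c2ccc(Cl)cc2Cl)CC(C)OC(C)=O)cc1` likewise gives only a limit, > 100000 nM.

Compound 1 and compound 3 share a core and differ by one change, (methyl in place of hydrogen on a saturated chain carbon bound to an oxygen next to a carbonyl group and a saturated chain carbon); in this assay that change gave an at least 1.1-fold higher number from compound 1 to compound 3 (0.07 log units; that floor lies within the scatter). The limit at which compound 3 sits is the limit of > 100000 nM in this assay, at which 2 of the 3 values shown sit, which holds two of the three values here. How the core of compound 2 differs from that of compound 1 is not broken down here. Compound 4 `COc1ccc(C(=O)/C(=C/c2c(F)c(F)c(F)c(F)c2F)CC(C)OC(C)=O)cc1` carries the same change relative to compound 2: methyl in place of hydrogen on a saturated chain carbon bound to an oxygen next to a carbonyl group and a saturated chain carbon. Since compound 2 already sits at the limit and the earlier step read an at least 1.1-fold higher number from compound 1 to compound 3 (0.07 log units; that floor lies within the scatter), compound 4 is expected to sit at the limit as well. The estimated step from compound 2 to compound 4 is a step that the limit leaves unreadable from compound 2 to compound 4. Compound 4 is therefore estimated at 160000 nM, expected between 90000 nM and 400000 nM, most likely reported only as a limit.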

Compound 4, half-maximal inhibitory concentration: > 100000 nM
Compound 4 was reported as a limit; the forecaster's own chance of this, stated with the estimate: 90%; the middle value lies beyond the limit too.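

Compound 2 and compound 4 each give only a limit, so the step between them cannot be read: the limit of > 100000 nM in this assay, at which 3 of the 4 values shown sit.

The compounds shown leave open how strongly either one inhibits in this assay, and whether the added methyl changes that at all.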